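A few compounds are considered here, and "the series" means these few. Any claim that something is new, unique, unknown or untested is made for them only; others in the source may bear on it.

Working notes on the series. Compound 1 `COc1ccc(-c2nc3cc(Cl)c(Cl)cc3[nH]2)cc1` and compound 2 `O=[N+]([O-])c1ccc(-c2nc3cc(C(F)(F)F)ccc3[nH]2)cc1` are built on different cores; the difference between the two cores is not broken down here. In an ADME assay on Vero cells (Chlorocebus sabaeus) for cytotoxicity (a higher number here means that more compound is tolerated, a lower number that less compound is tolerated), compound 1 gives 30000 nM, and compound 2 gives 45000 nM. Compound 3 `O=[N+]([O-])c1ccc(-c2nc3cc(C(F)(F)F)ccc3[nH]2)c([N+](=O)[O-])c1` is compound 2 with nitro in place of hydrogen on an aromatic carbon; in this assay compound 3 gives 25000 nM, which makes the step of a 1.8-fold lower number from compound 2 to compound 3 (0.26 log units; within the scatter). Compound 4 `COc1ccc(-c2nc3cc(Cl)c(Cl)cc3[nH]2)c([N+](=O)[O-])c1` is not yet measured; it is compound 1 with nitro in place of hydrogen on an aromatic carbon. This is the same kind of change as from compound 2 to compound 3, though not the same: in compound 4 the entering nitro sits meta to a methoxy group, whereas in compound 3 it sits meta to a nitro group. Among the compounds with values here, with only one earlier example, the step of a 1.5-fold lower number from compound 1 to compound 4 (0.18 log units; within the scatter) is expected to be small, resting on the earlier step of a 1.8-fold lower number from compound 2 to compound 3 (0.26 log units; within the scatter), which stayed within the scatter. Compound 4 is therefore estimated at 20000 nM in this assay, with a range from 10000 nM to 45000 nM.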

Compound 4, half-maximal cytotoxic concentration: 80000 nM
Compound 4: middle estimate off by 4.0-fold (0.60 log units), on the low side, and the stated range ends below it.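

In this assay, nitro in place of hydrogen on an aromatic carbon gives a 2.7-fold higher number from compound 1 to compound 4 (0.43 log units; beyond the scatter), and the change does not carry over unchanged between the two cores: the same change on two cores in this assay, a 1.8-fold lower number (0.26 log units; within the scatter) from compound 2 to compound 3 and a 2.7-fold higher number (0.43 log units; beyond the scatter) from compound 1 to compound 4, 4.8-fold (0.68 log units) apart, beyond the scatter of two such steps

The step read on compound 2 and compound 3 was therefore no reliable guide to the step on the core of compound 1. These two pairs do not show why the steps differ: the cores differ, and so does the group already on the ring, a methoxy group in compound 4 and a nitro group in compound 3, and the two differences cannot be separated here.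

The compounds shown leave open whether the rise on the core of compound 1 belongs to nitro itself or would also appear with another entering group, such as an amine or a carboxylic acid. Also open, on these data alone, is how the same change behaves on a core that combines the methoxy group with trifluoromethyl, which would begin to separate the two differences.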